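Aryl change from compound 2 to compound 3

A few compounds are considered here, and "the series" means these few. Any claim that something is new, unique, unknown or untested is made for them only; others in the source may bear on it.

Of the compounds shown here, two have numbers so far. In a functional assay on PC-3 cells (Homo sapiens) for inhibition, read by MTT assay, with a stated time of 48 h, tested at 10 uM (a higher number here means more inhibition of growth at the concentration tested, a lower number less inhibition of growth), compound 1 `Cc1cc(=O)c2c(O)c(CN3CC(O)CC3C(=O)O)c(O)c([C@H]3CCN(C)C[C@H]3O)c2o1` gives 0%, and compound 2 `Cc1oc2c([C@H]3CCN(C)C[C@H]3O)c(O)cc(O)c2c(=O)c1C(O)c1ccc(Cl)cc1` gives 41%. Compound 2 is the higher of the two, and the gap between them lies beyond the usual scatter of the assay.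

Compound 3 `Cc1oc2c([C@H]3CCN(C)C[C@H]3O)c(O)cc(O)c2c(=O)c1C(O)c1c(F)cccc1Cl` is still unmeasured. It has 2-chloro-6-fluorophenyl in place of the 4-chlorophenyl of compound 2, on a saturated chain carbon bound to an aromatic carbon and an oxygen on a saturated carbon (2-chloro-6-fluorophenyl in place of 4-chlorophenyl on a saturated chain carbon bound to an aromatic carbon and an oxygen on a saturated carbon). Within the data shown here, no measured pair shows a change of this kind, so the size of the step has no direct precedent. The expectation therefore starts from compound 2 at 41%.

In this assay no step beyond the scatter is expected, and no firm direction, though the estimate sits slightly lower. The expected change is a number 3 percentage points lower from compound 2 to compound 3 (within the scatter). For compound 3 the estimated value is 38%, with an expected range of 15% to 62%.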

Compound 3, percent growth inhibition at one concentration: 0%
Compound 3: middle estimate off by 38 percentage points, on the high side; the measured number lies below the stated range.
By their numbers in this assay, from the lowest: compounds 1 and 3 (each within the scatter of the next); then compound 2.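

In this assay, among these compounds, the aryl group on a saturated chain carbon bound to an aromatic carbon and an oxygen on a saturated carbon proves to be a sensitive place: 2-chloro-6-fluorophenyl in place of 4-chlorophenyl gives a number 41 percentage points lower from compound 2 to compound 3 (beyond the scatter), the only one-place step so far. The shared core and the hydroxy-bearing chain carbon are the same in both compounds, so the growth inhibition of compound 2 depends on which aryl group sits at this carbon and not on those retained parts alone. The results at hand give no information on what lies behind this step.

The change adds a fluorine and also alters where the chlorine stands on the ring, and the compounds shown do not separate these two parts of the step. Open questions are whether 2-chlorophenyl or 2-fluorophenyl would retain the number of compound 2 or follow compound 3, and whether an unsubstituted phenyl, 4-fluorophenyl or 4-methoxyphenyl at the same carbon would hold the growth inhibition seen with 4-chlorophenyl.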